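Amide nitrogen methylation in the phenoxybenzylamine series

The compounds below may be only part of what the source reports. "The series", "measured", "known", "first", "only" and "open" are said of these compounds alone.

compound 1 `O=C(O)[C@H]1C[C@@H]1c1ccc(NCc2cccc(Oc3ccccc3)c2)cc1`: 12.3 nM; 13.5 nM (2 entries)
compound 2 `CNC(=O)CCc1ccc(NCc2cccc(Oc3ccccc3)c2)cc1`: 49 nM
compound 3 `CN(C)C(=O)CCc1ccc(NCc2cccc(Oc3ccccc3)c2)cc1`: not yet measured

In a functional assay on CHO cells for agonist activity at Free fatty acid receptor 1 (Homo sapiens) (on this read-out higher numbers stand for an effect only at larger amounts of compound and lower numbers for an effect already at smaller amounts), compound 1 gives 12.3 nM; 13.5 nM (2 entries) across repeated entries (the several entries of compound 1 in this assay, 12.3 nM; 13.5 nM (2 entries)). Compound 2 gives 49 nM in this assay, the only number shown for it, and a further entry without a single number. Compound 3 differs from compound 2 by methyl in place of hydrogen on an amide-type nitrogen. Within the data shown here, no step between measured compounds informs this change. A modest shift toward larger amounts is expected, the step of a 1.7-fold higher number from compound 2 to compound 3 (0.24 log units; within the scatter) likely near the edge of the scatter. Compound 3 is estimated at 85 nM, range 25 nM to 300 nM.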

Compound 3, half-maximal effective concentration: 174 nM
Estimate against measurement, compound 3: 2.0-fold (0.31 log units) below; low and high end bracket the measured number.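

In this assay, among these compounds, methyl in place of hydrogen on this amide-type nitrogen gives a 3.6-fold higher number from compound 2 to compound 3 (0.55 log units; beyond the scatter), the first reading at this position. The nitrogen is therefore not indifferent to this small change: going from methylcarbamoyl to dimethylcarbamoyl moves the number beyond the scatter. Nothing shown explains this step.

Still open, going by these compounds, is whether ethyl on this nitrogen, or a ring containing it, would shift the number further. The same applies to a carboxylic acid in place of the amide on the same chain.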